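A few compounds are considered here, and "the series" means these few. Any claim that something is new, unique, unknown or untested is made for them only; others in the source may bear on it.

Measured compounds:
compound 1, `Cc1ccc(OCC(=O)N(Cc2cccs2)c2c[nH]nc2C)cc1`, 0.4 nM
compound 2, `Cc1ccc(OCC(=O)N(Cc2cccs2)c2ncccn2)cc1`, 3700 nM
compound 3, `Cc1ccc(OCC(=O)N(Cc2cccs2)c2ccn[nH]2)cc1`, 0.2 nM

In an assay on HEK293 cells for agonist activity at transient receptor potential cation channel subfamily M member 8 (Homo sapiens), read by fluorescence and calcium flux, with a stated time of 15 min (on this read-out lower numbers stand for an effect already at smaller amounts and higher numbers for an effect only at larger amounts of compound), compound 3 gives the lowest number of the three. Its nearest neighbour is compound 1, a 2.0-fold lower number from compound 1 to compound 3 (0.30 log units; within the scatter), and its furthest is compound 2, a 19000-fold lower number from compound 2 to compound 3 (4.27 log units; beyond the scatter). Compound 4 is `Cc1ccc(OCC(=O)N(C)Cc2cccs2)cc1`; it differs from compound 3 in one place: methyl in place of 1H-pyrazol-5-yl on an amide-type nitrogen.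

Among the measured compounds shown here, two measured steps bear on this. Both show that the ring on the amide-type nitrogen decides the outcome: a 9300-fold higher number from compound 1 to compound 2 (3.97 log units; beyond the scatter), and in the other direction a 19000-fold lower number from compound 2 to compound 3 (4.27 log units; beyond the scatter). For the measured compounds named here, the step of a 2.0-fold lower number from compound 1 to compound 3 (0.30 log units; within the scatter) shows that one pyrazole ring can stand for another, but no measured compound lacks a ring at this place. Going by the values given here, since the only measured exchange of the pyrazole ring, for pyrimidin-2-yl, gave a large rise in the number, a methyl group, which brings no ring and no hydrogen-bond donor or acceptor, is expected to give a large rise as well, a 25000-fold higher number from compound 3 to compound 4 (4.40 log units; beyond the scatter). Compound 4 is therefore estimated at 5000 nM, with a range from 300 nM to 50000 nM.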

Compound 4, half-maximal effective concentration: 400 nM
Estimate against measurement, compound 4: 13-fold (1.10 log units) above; measured number inside the range.
By their numbers in this assay, from the lowest: compounds 3 and 1 (each within the scatter of the next); then compound 4; then compound 2.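

Compound 4 shows that the amide-type nitrogen needs no ring for an effect to be seen, although both pyrazole rings give far lower numbers than methyl (a 2000-fold higher number from compound 3 to compound 4 (3.30 log units; beyond the scatter); a 1000-fold higher number from compound 1 to compound 4 (3.00 log units; beyond the scatter)). It also shows that a ring at this place is no advantage in itself: pyrimidin-2-yl goes against any such rule, since replacing it with the much smaller methyl still lowers the number (a 9.3-fold lower number from compound 2 to compound 4 (0.97 log units; beyond the scatter)). No measurement shown here explains why these groups differ.

The compounds shown leave open where an ethyl group or a longer chain would fall, and whether a phenyl or imidazole ring would behave more like the pyrazoles or like pyrimidin-2-yl. They also leave open how an amine or a carboxylic acid carried on this nitrogen's substituent would compare.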